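The source may report more compounds than this note shows. Statements on the series, on what has been measured and on what is new or still open speak of the compounds shown alone.

Measured so far in a functional assay on MDA-MB-231 cells (Homo sapiens) for antiproliferative activity, read by MTT assay, with a stated time of 48 h; on this read-out higher numbers stand for weaker inhibition and lower numbers for stronger inhibition:
compound 1 `C=CS(=O)(=O)N1CCN(c2ncnc3sc(-c4ccc(C(F)(F)F)cc4)cc23)CC1` gives 6410 nM
compound 2 `C=CS(=O)(=O)N1CCN(c2ncnc3sc(-c4ccc(F)nc4)cc23)CC1` gives 16000 nM

Compound 2, at 16000 nM, holds the higher of the two numbers and so shows the weaker inhibition of the pair. Compound 3 `C=CS(=O)(=O)N1CCN(c2ncnc3sc(-c4c(C)noc4C)cc23)CC1` keeps the shared core but carries 3,5-dimethyl-1,2-oxazol-4-yl in place of 6-fluoropyridin-3-yl on an aromatic carbon, next to the ring sulfur (3,5-dimethyl-1,2-oxazol-4-yl in place of 6-fluoropyridin-3-yl on an aromatic carbon). Among the compounds with values here, only one measured step bears on this change, a swap of one aromatic group for another on that same carbon: a 2.5-fold higher number from compound 1 to compound 2 (0.40 log units; beyond the scatter), which is modest. A step of similar or smaller size is therefore expected in this assay, and the data fix no direction for it. The estimated step is a 1.1-fold lower number from compound 2 to compound 3 (0.06 log units; within the scatter), so none beyond the scatter is expected. For compound 3 the estimate is 14000 nM (expected range 5000 nM to 40000 nM).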

Compound 3, half-maximal inhibitory concentration: 28200 nM
The estimate for compound 3 lay 2.0-fold (0.30 log units) below the measured number; the range from low to high includes it.
By their numbers in this assay, from the lowest: compound 1; then compounds 2 and 3 (each within the scatter of the next).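

In this assay, replacing 6-fluoropyridin-3-yl with 3,5-dimethyl-1,2-oxazol-4-yl on the aromatic carbon next to the ring sulfur gives a 1.8-fold higher number from compound 2 to compound 3 (0.25 log units; within the scatter) and so does not separate these two rings at this position. Replacing 4-(trifluoromethyl)phenyl with the same oxazole gives a 4.4-fold higher number from compound 1 to compound 3 (0.64 log units; beyond the scatter) and leaves compound 1 with the strongest inhibition of the three, since its steps to both other compounds lie beyond the scatter. Nothing measured here gives a reason for these differences.

The compounds shown do not tell whether the trifluoromethyl group or the phenyl ring that carries it sets compound 1 apart. An unsubstituted phenyl, or a phenyl bearing a methoxy group or an amine, at this position would bear on that question.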